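Swapping chloro for methyl in an inactive series

The source may hold more compounds than are shown below. What is called first, only, known or untested is meant among the compounds shown, and "the series" means these compounds.

Compound 3 `CCCc1nnc(SCC(=O)c2ccc(Cl)cc2)n1N1C(=O)c2ccccc2C1=O` was tested in a functional assay on MKN-45 cells (Homo sapiens) for cytotoxicity, read by MTT assay, with a stated time of 48 h; on this read-out lower numbers stand for stronger inhibition and higher numbers for weaker inhibition. In this assay compound 3 reaches only the limit > 200000 nM, not a number. Compound 1 `Cc1ccc(C(=O)CSc2nnc(C)n2N2C(=O)c3ccccc3C2=O)cc1` also stops at the limit > 200000 nM in this assay. Compound 2 `C=CCSc1nnc(CCC)n1N1C(=O)c2ccccc2C1=O` likewise gives only the limit > 200000 nM. For the measured compounds named here, the one step between neighbours, a step that the two limits leave unreadable from compound 2 to compound 3, cannot be read; both of its ends are limits, and all three values sit at the limit of > 200000 nM in this assay, at which 3 of the 3 values shown sit. Compound 4 `CCCc1nnc(SCC(=O)c2ccc(C)cc2)n1N1C(=O)c2ccccc2C1=O` differs from compound 3 by methyl in place of chloro on an aromatic carbon. No measured step bears on this change, and nothing shown points to a gain. Compound 4 is therefore expected to remain at the limit, with a step that the limit leaves unreadable from compound 3 to compound 4 expected to stay within the scatter. Compound 4 is estimated at 300000 nM, in the range 150000 nM to 1000000 nM.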

Compound 4, half-maximal inhibitory concentration: > 200000 nM
Compound 4 was reported as a limit; the forecaster's own chance of this, stated with the estimate: 85%; the middle value is on the limit's open side.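

In this assay compound 4 gives only the limit > 200000 nM, so its steps from compound 1, compound 2 and compound 3 cannot be read: the limit of > 200000 nM in this assay, at which 4 of the 4 values shown sit.

The compounds shown leave open whether any change to the shared core would give a number rather than a limit.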